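The source may report more compounds than this note shows. Statements on the series, on what has been measured and on what is new or still open speak of the compounds shown alone.

In a functional assay on HT-29 cells (Homo sapiens) for cytotoxicity, read by MTT assay, with a stated time of 72 h (on this read-out lower numbers stand for higher toxicity in this test and higher numbers for lower toxicity in this test), compound 1, `CS/C(=N\C(=O)c1ccno1)NC(=O)c1ccno1`, gives > 100000 nM, which is a limit of the test rather than a measured number. Compound 2, `C[Se]/C(=N\C(=O)c1cccs1)NC(=O)c1cccs1`, is the second compound with a value here. In this assay compound 2 gives > 100000 nM, again a limit and not a number. Where compound 2 stands is therefore told only by the limit of > 100000 nM in this assay, at which 2 of the 2 values shown sit: both known values sit at the ceiling of the test, so no step between the two has been counted and nothing separates them on the numbers shown. Compound 3, `O=C(/N=C(/NC(=O)c1cccs1)[Se]Cc1ccccc1)c1cccs1`, differs from compound 2 in one place: phenyl in place of hydrogen on a saturated chain carbon bound to a selenium atom. For the measured compounds named here, with both known values resting on a limit there is no measured step to lean on, and no shift beyond the usual scatter is expected from this exchange. The step from compound 2 to compound 3 is estimated at a number no higher from compound 2 to compound 3 (the limit leaves the size open), that is to say essentially none. For compound 3 the expected value in this assay is 100000 nM, within a range from 30000 nM to 300000 nM, with a good chance that the test again reports only a limit.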

Compound 3, concentration lethal to 50% of the cells: > 100000 nM
Compound 3 gave a limit, no number (the forecaster's own chance of this, stated with the estimate: 70%); the middle value lies on the limit itself.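

No step can be read from compound 2 to compound 3, because both values are limits of the test and not numbers: the limit of > 100000 nM in this assay, at which 3 of the 3 values shown sit.

The compounds shown leave open whether the exchange of methyl for benzyl changes anything in this assay, and which change to the shared core, if any, would give a measured number there.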